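A few compounds are considered here, and "the series" means these few. Any claim that something is new, unique, unknown or untested is made for them only; others in the source may bear on it.

Measured compounds in a functional assay on ECa-109 cells for inhibition, with ECa-109 cell line (Homo sapiens) as the target, read by sulforhodamine B assay; a lower number here means a stronger inhibitor, a higher number a weaker inhibitor:
Compound 1 `Cc1ccc(NC2=CC(=O)c3nc4n(c3C2=O)[C@H]2OC[C@@H](O)[C@H]2OC4)cc1` — compound 1 gives 3480 nM.
Compound 2 `CCCc1ccc(NC2=CC(=O)c3c(nc4n3[C@H]3OC[C@@H](O)[C@H]3OC4)C2=O)cc1` — compound 2 gives > 4000 nM, which is a limit of this assay and not a number.

Compound 2 therefore stands at the weak end of what has been seen so far; its value is one of the two shown, and the limit of > 4000 nM in this assay, at which 1 of the 2 values shown sits, marks where it sits. Among the measured compounds shown here, compound 1 is the only member with a measured number, and no step between measured compounds is set out, so the series offers no measured direction for the next change.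

Compound 3 `O=C1C(NCc2ccccc2)=CC(=O)c2c1nc1n2[C@H]2OC[C@@H](O)[C@H]2OC1` is the untested member. It differs from compound 2 in one place: benzyl in place of 4-propylphenyl on an amine nitrogen. With compound 2 resting at a limit, the step from compound 2 to compound 3 can only be judged against that limit and against compound 1, and the expectation is no step beyond the scatter, as a step that the limit leaves unreadable from compound 2 to compound 3 states. Compound 3 is expected to give about 4500 nM in this assay, with a range from 1500 nM to 14000 nM, and a real chance that only a limit is reported again.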

Compound 3, half-maximal inhibitory concentration: > 8000 nM
Compound 3 ended at the assay's limit (the forecaster's own chance of this, stated with the estimate: 55%); middle value at least 1.7-fold (0.24 log units) from the limit.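

Compound 2 and compound 3 both rest at limits of this assay, not at numbers, and no step can be read between them. The compounds shown leave open how far either compound lies beyond its limit, and whether benzyl and 4-propylphenyl on the amine nitrogen differ at all in this assay.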